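The compounds below may be only part of what the source reports. "The series", "measured", "known", "first", "only" and "open" are said of these compounds alone.

Compound 1, `Cc1ccc(S(=O)(=O)NC(C)C)cc1C#Cc1cc(Cl)ccc1OCC(=O)O`, gives 0.004 in an ADME assay on a cell-free system (plasma, Homo sapiens); a higher number here means a larger unbound share of the compound, a lower number a smaller unbound share. Compound 2, `Cc1ccc(S(C)(=O)=O)cc1C#Cc1cc(Cl)ccc1OCC(=O)O`, gives 0.017 in this assay.

Compound 2 holds the higher of the two numbers in this assay; compound 1 sits a 4.3-fold higher number from compound 1 to compound 2 (0.63 log units; beyond the scatter). Compound 3, `Cc1ccc(S(=O)(=O)N(C)C)cc1C#Cc1cc(Cl)ccc1OCC(=O)O`, has not been measured. It differs from compound 2 by dimethylamino in place of methyl on a sulfonyl sulfur. Among the measured compounds shown here, the one measured step bears on this: the step from compound 1 to compound 2 went in the other direction, a 4.3-fold higher number from compound 1 to compound 2 (0.63 log units; beyond the scatter), and was modest. A step of similar kind but smaller is therefore expected here, downward, with compound 3 expected to fall a 2.1-fold lower number from compound 2 to compound 3 (0.33 log units; beyond the scatter). The estimate for compound 3 is 0.008, in the range 0.004 to 0.017.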

Compound 3, unbound fraction: 0.004
Compound 3: middle estimate off by 2.0-fold (0.30 log units), on the high side; the measured number falls inside the stated range.
By their numbers in this assay, from the lowest: compounds 1 and 3 (each within the scatter of the next); then compound 2.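

In this assay dimethylamino in place of methyl on a sulfonyl sulfur gives a 4.3-fold lower number from compound 2 to compound 3 (0.63 log units; beyond the scatter) and so matches in size the step seen with isopropylamino. The two amino groups read alike at this position, with no change at the digits printed from compound 1 to compound 3 (within the scatter) between them, so methyl alone stands apart among the three compounds. Nothing available accounts for this difference. The compounds shown leave open whether an unsubstituted amino group, a cyclic amine such as morpholine or a longer carbon chain on that sulfur would read with methyl or with the two amino groups.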